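The compounds below may be only part of what the source reports. "The series", "measured", "known", "first", "only" and "open" are said of these compounds alone.

Measured so far in an ADME assay on NIH3T3 cells (Mus musculus) for cytotoxicity, with a stated time of 72 h; a lower number here means a stronger inhibitor, a higher number a weaker inhibitor:
- compound 1 `OC[C@H]1O[C@@H](n2cnc3c(NCc4cccc(F)c4)ncnc32)[C@H](O)[C@@H]1O`: 84000 nM
- compound 2 `OC[C@H]1O[C@@H](n2cnc3c(NCc4ccccc4Cl)ncnc32)[C@H](O)[C@@H]1O`: > 166000 nM

Compound 2 stands at the limit of > 166000 nM in this assay, at which 1 of the 2 values shown sits, so its entry is a limit and not a number.

Compound 3 `Cc1cccc(CNc2ncnc3c2ncn3[C@@H]2O[C@H](CO)[C@@H](O)[C@H]2O)c1` has 3-methylphenyl in place of 2-chlorophenyl, on a saturated chain carbon bound to a nitrogen on an aromatic ring: 3-methylphenyl in place of 2-chlorophenyl on a saturated chain carbon bound to a nitrogen on an aromatic ring.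

Going by the values given here, one measured step bears on this change, 3-fluorophenyl going to 2-chlorophenyl at the same place: an at least 1.9-fold higher number from compound 1 to compound 2 (0.29 log units; that floor lies within the scatter). That step gives no firm direction in this assay. The group entering compound 3 is a different one, and the nearest reference is compound 1 at 84000 nM. No step beyond the scatter is therefore expected, and any shift should be towards a lower number, with the expected step being an at least 1.6-fold lower number from compound 2 to compound 3 (0.22 log units; that floor lies within the scatter). A further limit reading remains possible.

For compound 3 the estimated value is 100000 nM, with an expected range of 40000 nM to 200000 nM.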

Compound 3, half-maximal inhibitory concentration: > 166000 nM
Compound 3: no number, only a limit; the forecaster's own chance of this, stated with the estimate: 40%; at least 1.6-fold (0.22 log units) between middle value and limit.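

In this assay the reading for compound 3 is a limit and not a number, as is the reading for compound 2: the limit of > 166000 nM in this assay, at which 2 of the 3 values shown sit. The step between these two limits cannot be read, so 2-chlorophenyl and 3-methylphenyl on a saturated chain carbon bound to a nitrogen on an aromatic ring remain unordered. Methyl in place of fluoro on an aromatic carbon gives an at least 1.9-fold higher number from compound 1 to compound 3 (0.29 log units; that floor lies within the scatter), so a second change from compound 1 also ends in a limit and again sets no firm direction.

Going by these compounds alone, compound 1 remains the only compound here with a number, which leaves the true size of both changes open. As far as these compounds go, whether unsubstituted phenyl, 3-chlorophenyl or a longer chain at this place would give a number in this assay also stays open.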